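A few compounds are considered here, and "the series" means these few. Any claim that something is new, unique, unknown or untested is made for them only; others in the source may bear on it.

Measured compounds:

Compound 1, `CC(=O)N1N=C(c2ccco2)CC1c1cccc([N+](=O)[O-])c1`: 20000 nM
Compound 2, `CC(=O)N1N=C(c2ccco2)CC1c1ccc([N+](=O)[O-])cc1`: 21300 nM

In a functional assay on PC-3 cells (Homo sapiens) for cytotoxicity, read by sulforhodamine B assay, with a stated time of 48 h (on this read-out higher numbers stand for weaker inhibition and lower numbers for stronger inhibition), compound 1 gives 20000 nM, and in the same read-out compound 2 gives 21300 nM. Compound 2 holds the higher of the two numbers, but its only neighbor, compound 1, lies so close that the gap falls within the usual scatter, so neither compound can be called the weaker or the stronger of the pair. Both sit at the weak end of what a cytotoxicity read-out on this cell line usually reports.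

The unmeasured compound 3, `CC(=O)N1N=C(c2ccco2)CC1c1ccc(Br)cc1`, departs from compound 2 by a single change: bromo in place of nitro on an aromatic carbon. Among the compounds with values here, no measured pair shows this exchange, so nothing in the data sets its size or direction. What the two measured compounds do show is that a nitro group at two different positions on that ring leaves the number essentially unchanged, which gives no footing for a large move in either direction. The step from compound 2 to compound 3 in this assay is therefore expected to stay within the scatter, a 1.1-fold lower number from compound 2 to compound 3 (0.03 log units; within the scatter). For compound 3 the estimated value is 20000 nM, with a range from 7000 nM to 60000 nM.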

Compound 3, half-maximal inhibitory concentration: 42100 nM
The estimate for compound 3 lay 2.1-fold (0.32 log units) below the measured number, within the range that was stated.
By their numbers in this assay, from the lowest: compounds 1, 2 and 3 (each within the scatter of the next, the first and the last beyond it).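

In this assay, bromo in place of nitro on an aromatic carbon, para to a large group, gives a 2.0-fold higher number from compound 2 to compound 3 (0.30 log units; within the scatter), a step printed as within the scatter. The earlier compounds shown here showed only nitro at two places on the ring; this result adds a different kind of substituent at one of those places. Here three heavy atoms with two hydrogen-bond acceptors give way to one heavy atom with none, and the two numbers still cannot be told apart, so this place tolerates this exchange without a step beyond the scatter, while no information bears on what lies behind that reading.

With only nitro and bromo shown at this place, it stays open whether an amine, a carboxylic acid or a longer chain on the same carbon would produce a step beyond the scatter, or would likewise leave the number in this range. Going by these compounds, it also stays open whether bromo would read the same where compound 1 carries its nitro group, and whether the same exchange would behave alike on a different core.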